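The source may report more compounds than this note shows. Statements on the series, on what has been measured and on what is new or still open speak of the compounds shown alone.

Measured in a functional assay on PC-3 cells (Homo sapiens) for cytotoxicity, read by MTT assay, with a stated time of 72 h; on this read-out lower numbers stand for stronger inhibition and higher numbers for weaker inhibition:
- compound 1 `O=C(/C=C/c1ccc([N+](=O)[O-])cc1)Nc1cc2c(Nc3ccc(F)c(Cl)c3)ncnc2cc1O[C@H]1CCOC1`: 22800 nM
- compound 2 `COc1ccc(OC)c(/C=C/C(=O)Nc2cc3c(Nc4ccc(F)c(Cl)c4)ncnc3cc2O[C@H]2CCOC2)c1`: 8730 nM

Compound 2 holds the lower of the two numbers, at 8730 nM. Compound 3 `COc1cc(/C=C/C(=O)Nc2cc3c(Nc4ccc(F)c(Cl)c4)ncnc3cc2O[C@H]2CCOC2)cc(OC)c1` differs from it as follows: 3,5-dimethoxyphenyl in place of 2,5-dimethoxyphenyl on a double-bonded chain carbon bound to a double-bonded chain carbon. Within the data shown here, only one measured step bears on this change, the modest 2.6-fold lower number from compound 1 to compound 2 (0.42 log units; beyond the scatter), which was made at the same place. Among the measured compounds shown here, no measured step compares two dimethoxyphenyl groups, so the direction is open, and a step of similar modest size or none beyond the scatter is expected. The expected change is a 1.1-fold higher number from compound 2 to compound 3 (0.06 log units; within the scatter). For compound 3 the estimated value is 10000 nM, with an expected range of 4000 nM to 25000 nM.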

Compound 3, half-maximal inhibitory concentration: 25600 nM
Beside the measured number, compound 3's estimate is 2.6-fold (0.41 log units) below it; measured number above the stated range.
By their numbers in this assay, from the lowest: compound 2; then compounds 1 and 3 (each within the scatter of the next).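

In this assay the placing of the two methoxy groups matters: 3,5-dimethoxyphenyl in place of 2,5-dimethoxyphenyl gives a 2.9-fold higher number from compound 2 to compound 3 (0.47 log units; beyond the scatter) even though the two groups hold the same atoms. Carrying two methoxy groups is thus not enough to lower the number, since 3,5-dimethoxyphenyl in place of 4-nitrophenyl gives a 1.1-fold higher number from compound 1 to compound 3 (0.05 log units; within the scatter) and the change lies within the scatter. Nothing measured here explains the difference between the two dimethoxyphenyl groups. As far as these compounds go, whether a plain phenyl, a hydroxyphenyl or an aminophenyl group at this place would give a number lower than that of compound 2 stays open.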